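The source may hold more compounds than are shown below. What is called first, only, known or untested is meant among the compounds shown, and "the series" means these compounds.

Working notes on the series.

Compound 2 `COc1cc2nccc(Oc3ccc(Nc4nn(C)cc4C(=O)NCC4CCCO4)cc3)c2cc1C(N)=O` is the reference point here. In a functional assay on BaF3 cells (Mus musculus) for antiproliferative activity, read by CCK-8 assay and cell counting, with a stated time of 76 h (a lower number here means a stronger inhibitor, a higher number a weaker inhibitor), compound 2 gives > 10000 nM, which is a limit of the assay and not a number. Within the data shown here, its only measured neighbour is compound 1 `COc1cc2nccc(Oc3ccc(Nc4nn(C)cc4C(=O)NOCc4ccccc4)cc3)c2cc1C(N)=O`, which differs in the group on the amide-type nitrogen. In this assay compound 1 gives > 10000 nM, likewise a limit. The step that the two limits leave unreadable from compound 1 to compound 2 therefore cannot be read; both values sit at the limit of > 10000 nM in this assay, at which 2 of the 2 values shown sit, and nothing in the measured pair says how far either compound lies beyond that limit.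

Compound 3 `COc1cc2nccc(Oc3ccc(Nc4nn(C)cc4C(=O)N4CCCCC4)cc3)c2cc1C(N)=O` is the next compound to be measured. The change from compound 2 is piperidin-1-yl in place of ((oxolan-2-yl)methyl)amino on a carbonyl carbon.

No measured step bears on this change with a readable size, and the one step shown is itself unreadable. The expectation is therefore no shift beyond the scatter, with the most likely outcome that compound 3 again reports only a limit. For compound 3 the estimate in this assay is 10000 nM, within a range of 3000 nM to 30000 nM. The expected step of a number no higher from compound 2 to compound 3 (the limit leaves the size open) is accordingly set at none beyond the scatter.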

Compound 3, half-maximal inhibitory concentration: 5650 nM
For compound 3 the middle estimate is 1.8-fold (0.25 log units) above the measured one; low and high end bracket the measured number.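

In this assay, among these compounds, compound 3 gives 5650 nM, the only readable number among the three compounds, so the group on this carbonyl carbon can make the difference to a readable number. The change from ((oxolan-2-yl)methyl)amino reads as an at least 1.7-fold lower number from compound 2 to compound 3 (0.24 log units; that floor lies within the scatter), and the change from (benzyloxy)amino reads as an at least 1.7-fold lower number from compound 1 to compound 3 (0.24 log units; that floor lies within the scatter); both are floors set by a limit, so the true sizes may be larger. Compound 1 and compound 2 each remain a limit and not a number: the limit of > 10000 nM in this assay, at which 2 of the 3 values shown sit.

Among the compounds shown here, how far compound 1 and compound 2 lie beyond that limit stays open, so the step between them still cannot be read, and the single pair does not tie the reading of compound 3 to the 0 hydrogen-bond donors of piperidin-1-yl against the 1 of ((oxolan-2-yl)methyl)amino. Also open, from the compounds shown here alone, is whether another group on this carbonyl carbon, such as pyrrolidin-1-yl, morpholin-4-yl or the open-chain dimethylamino, would give a readable number in this assay.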